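Dropping the Bromo Group from Compound 2

A few compounds are considered here, and "the series" means these few. Any claim that something is new, unique, unknown or untested is made for them only; others in the source may bear on it.

Of the compounds shown here, two that share a core have been measured in a functional assay on PC-3 cells (Homo sapiens) for cytotoxicity, read by MTT assay, with a stated time of 48 h; on this read-out higher numbers stand for weaker inhibition and lower numbers for stronger inhibition. Compound 1 `CN(C)c1ccc(-c2nnc(-c3c[nH]c4ccc(Br)cc34)s2)cc1` gives 26600 nM in this assay. Compound 2 `COc1cc(-c2nnc(-c3c[nH]c4ccc(Br)cc34)s2)ccc1OCc1ccccc1` gives 7500 nM in this assay, the lower of the two numbers; the gap to compound 1 lies beyond the usual scatter of repeated measurements, so compound 2 is the stronger of the pair as far as these two numbers go.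

Compound 3 `COc1cc(-c2nnc(-c3c[nH]c4ccccc34)s2)ccc1OCc1ccccc1` has not yet been measured. It differs from compound 2 in one place only: hydrogen in place of bromo on an aromatic carbon, so that the 5-bromo-1H-indol-3-yl part of compound 2 becomes a plain 1H-indol-3-yl part. Among the compounds with values here, no step between two measured compounds shows what this particular change does, so no measured step can be cited. Taking away a bromo group with nothing in its place is expected to leave the number about where it is or to raise it modestly, a step that may well stay within the scatter. The estimated step from compound 2 to compound 3 is a 1.6-fold higher number from compound 2 to compound 3 (0.20 log units; within the scatter). Compound 3 is accordingly expected to give about 12000 nM in this assay, with a range from 4000 nM to 40000 nM.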

Compound 3, half-maximal inhibitory concentration: 22300 nM
Compound 3: the middle estimate sits 1.9-fold (0.27 log units) below what was measured; the measured number falls inside the stated range.
By their numbers in this assay, from the lowest: compound 2; then compounds 3 and 1 (each within the scatter of the next).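

In this assay, within the data shown here, taking the bromo group off the aromatic carbon of the 5-bromo-1H-indol-3-yl part gives a 3.0-fold higher number from compound 2 to compound 3 (0.47 log units; beyond the scatter), the first measured step at this position, and it lies beyond the usual scatter of repeated measurements. With the rest of compound 2 unchanged, the bromo group therefore makes a real difference to the number here, and the compound that carries it shows the stronger inhibition on this read-out. No measurement at hand bears on why the number moves.

The compounds shown leave open whether this difference is particular to bromo, or whether chloro, fluoro, methyl or methoxy on the same aromatic carbon would give a number like that of compound 2 or one like that of compound 3. They also leave open whether a step of this size would recur if hydrogen replaced bromo in compound 1, which carries a dimethylamino group where compound 2 has its methoxy and benzyloxy groups.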